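Removing the Amino Group from the Benzyl Substituent

The source may hold more compounds than are shown below. What is called first, only, known or untested is meant among the compounds shown, and "the series" means these compounds.

compound 1 `CC(=O)Nc1cccc(Cn2cc(-c3ccc4cn[nH]c4c3)ccc2=O)c1` — 43 nM
compound 2 `Nc1cccc(Cn2cc(-c3ccc4cn[nH]c4c3)ccc2=O)c1` — 84 nM

In an assay for inhibition of MAP kinase-interacting serine/threonine-protein kinase 2 (Homo sapiens), read by luminescence and ADP-Glo, with a stated time of 2 h (a higher number here means a weaker inhibitor, a lower number a stronger inhibitor), compound 1 gives 43 nM, and compound 2 gives 84 nM. Of these two numbers, compound 2 is separated from compound 1 only by a 2.0-fold higher number from compound 1 to compound 2 (0.29 log units; within the scatter), so the two compounds cannot be told apart on this evidence. The next compound, compound 3 `O=c1ccc(-c2ccc3cn[nH]c3c2)cn1Cc1ccccc1`, takes the change one step further: hydrogen in place of amino on an aromatic carbon. Among the compounds with values here, the only measured step that bears on it is the one from compound 1 to compound 2, which swapped acetyl for hydrogen on that same nitrogen and stayed within the scatter. Within the data shown here, no measured pair shows what happens when the nitrogen itself is removed, so the expectation rests on that single small step. For compound 3 a step of about a 1.4-fold higher number from compound 2 to compound 3 (0.15 log units; within the scatter) in this assay is expected, most likely toward a modestly higher number. Compound 3 is therefore estimated at 120 nM, with a range from 45 nM to 320 nM.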

Compound 3, half-maximal inhibitory concentration: 75 nM
For compound 3 the middle estimate is 1.6-fold (0.20 log units) above the measured one; the range from low to high includes it.
By their numbers in this assay, from the lowest: compounds 1, 3 and 2 (each within the scatter of the next).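

In this assay, removing the amino group gives a 1.1-fold lower number from compound 2 to compound 3 (0.05 log units; within the scatter), and removing the whole acetamido group gives a 1.7-fold higher number from compound 1 to compound 3 (0.24 log units; within the scatter). The earlier pair showed only that the amino and acetamido groups could not be told apart; these steps extend that to the plain benzyl, so the ring needs neither group for compound 3 to stay within the scatter of both compounds that carry one. No measurement shown explains why the three compounds read alike.

All three compounds therefore lie within the scatter of one another, so the shown changes at this ring carbon reveal no trend. From the compounds shown here alone, it remains open whether a different group there, such as a carboxylic acid or a longer chain ending in an amine, would move the number beyond the scatter.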